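Aryl swap on the ring nitrogen of compound 2

The source may report more compounds than this note shows. Statements on the series, on what has been measured and on what is new or still open speak of the compounds shown alone.

Measured so far:
compound 1, `COc1ccccc1N1C(=O)CSC1c1cc(F)cc(C(=O)O)c1`, 0%
compound 2, `COc1ccc(OC)c(N2C(=O)CSC2c2cccc(C(=O)NCCCCc3ccccc3)c2)c1`, 48%
compound 3, `COc1ccccc1N1C(=O)CSC1C(=O)NCCCCc1ccccc1`, 14%

All three numbers come from a functional assay on SJSA-1 cells (Homo sapiens) for inhibition, read by CCK-8 assay, with a stated time of 72 h, tested at 1 uM; a lower number here means less inhibition, a higher number more inhibition at the concentration tested (going by the name of the read-out). Compound 2 stands highest of the three in this assay: compound 3 lies below it by a gap beyond the scatter, and compound 1 lies further below, also beyond the scatter. Compound 1 carries an acid where compound 2 carries the amide-linked chain; compound 3 carries that chain directly on the five-membered ring. For the measured compounds named here, no single-change pair among the measured compounds is available, so no measured step can be quoted.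

Compound 4, `CC(F)(F)c1cccc(N2C(=O)CSC2c2cccc(C(=O)NCCCCc3ccccc3)c2)c1`, has not been measured. It differs from compound 2 in one place: a group of 10 heavy atoms (8 carbon, 2 fluorine; one six-membered aromatic ring of carbon only) in place of a group of 10 heavy atoms (8 carbon, 2 oxygen; one six-membered aromatic ring of carbon only), on an amide-type nitrogen in a ring. The 2,5-dimethoxyphenyl leaves and the group of eight carbon and two fluorine atoms enters, on an amide-type nitrogen in a ring. Going by the values given here, nothing among the measured compounds shows how this assay responds to a change at that position while the amide-linked chain is kept, so the expected step is uncertain.

The expectation is a modest downward step, a number 10 percentage points lower from compound 2 to compound 4 (within the scatter), near the edge of the scatter. Compound 4 is estimated at 38%, within a range from 10% to 65%.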

Compound 4, a percentage reported as inhibition, at one concentration (the size of the read-out at that concentration, not a potency): 68%
Compound 4: middle estimate off by 30 percentage points, on the low side; measured number outside the range, above it.
By their numbers in this assay, from the lowest: compound 1; then compound 3; then compound 2; then compound 4.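

In this assay, for the compounds shown here, the amide-type nitrogen in the ring accepts a change of aryl group while the amide-linked chain is kept: replacing the 2,5-dimethoxyphenyl gives a number 20 percentage points higher from compound 2 to compound 4 (beyond the scatter), the only single-place step so far. This position therefore bears on the read-out, and the 2 hydrogen-bond acceptors of the 2,5-dimethoxyphenyl are not required for inhibition at the concentration tested. Nothing available explains the size or direction of this step.

One step cannot separate the contribution of the fluorine atoms from that of their placement on the aryl group, and a single concentration gives no potency. A trifluoromethyl or a nitrile on that aryl group would show whether the higher inhibition extends beyond this one replacement.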